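The compounds below may be only part of what the source reports. "The series", "measured", "known", "first", "only" and "open" are said of these compounds alone.

The compounds measured so far in an ADME assay on microsomes from liver (Homo sapiens) for metabolic stability, tested at 2.5 uM (a lower number here means slower removal, a higher number faster removal of the compound), are:

compound 1, `Brc1cccc2c1nnn2CC1CC1`: 1.3 mL/min/g
compound 2, `Fc1cccc2c1nnn2CC1CC1`: "not determined" (no result reported)
compound 3, `COc1cccc2c1nnn2CC1CC1`: 1.8 mL/min/g

Among the measured compounds shown here, compound 3 gives the higher of the two numbers reported, and its nearest neighbour is compound 1; the only step among measured compounds, a 1.4-fold higher number from compound 1 to compound 3 (0.14 log units; within the scatter), lies within the scatter, so the two values cannot be told apart in this assay. Compound 2 contributes no number.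

Compound 4, `FC(F)(F)c1cccc2c1nnn2CC1CC1`, is the next compound. It differs from compound 3 in one place:

trifluoromethyl in place of methoxy on an aromatic carbon

For the measured compounds named here, the only measured step that bears on compound 4 at all is the exchange at the same aromatic carbon from compound 1 to compound 3, and that step was within the scatter. Going by the values given here, no measured compound carries a trifluoromethyl group, so the size of the present change has not been observed. On the available numbers the expectation is that compound 4 stays close to compound 3, with an expected step of a 1.2-fold lower number from compound 3 to compound 4 (0.08 log units; within the scatter) in this assay, not clearly beyond the scatter in either direction. Compound 4 is therefore estimated at 1.5 mL/min/g, within a range from 0.7 mL/min/g to 3.2 mL/min/g.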

Compound 4, intrinsic clearance in a liver preparation (reported as CLH), per the amount of preparation that the assay uses: 0.3 mL/min/g
Estimate against measurement, compound 4: 5.0-fold (0.70 log units) above; the measured number lies below the stated range.
By their numbers in this assay, from the lowest: compound 4; then compounds 1 and 3 (each within the scatter of the next).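

In this assay, the exchange of methoxy for bromo on this aromatic carbon had left the two numbers indistinguishable (a 1.4-fold higher number from compound 1 to compound 3 (0.14 log units; within the scatter)), but trifluoromethyl at the same carbon separates clearly from both groups (a 6.0-fold lower number from compound 3 to compound 4 (0.78 log units; beyond the scatter); a 4.3-fold lower number from compound 1 to compound 4 (0.64 log units; beyond the scatter)). The position is therefore not indifferent to what it carries, and with both steps beyond the scatter, compound 4 has the lowest number of the three compounds with a reported value. Nothing in the data given accounts for this drop, and no accompanying measurement bears on it.

On these data alone, whether the low number is particular to trifluoromethyl stays open, as compound 2 contributes no number and the three values alone cannot show how a nitrile, a chloro group or a difluoromethyl group would fare on this carbon. As far as these compounds go, all the compounds also keep the rest of the structure unchanged, so it remains unknown whether trifluoromethyl would give a similar step alongside an amine or a longer chain elsewhere on the core.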